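The source may hold more compounds than are shown below. What is called first, only, known or untested is meant among the compounds shown, and "the series" means these compounds.

Measured compounds in a functional assay on MV4-11 cells (Homo sapiens) for antiproliferative activity, with a stated time of 6 days, tested at 6.25 uM; on this read-out higher numbers stand for a stronger effect at the one concentration tested and lower numbers for a weaker effect:
- compound 1 `CNC(=O)N1CCCc2ccc(NC(=O)c3cccc(-c4cnn(S(C)(=O)=O)c4)c3)cc21`: 18%
- compound 2 `CNC(=O)N1CCCc2ccc(NC(=O)c3ccc(-c4cc[nH]n4)cc3)cc21`: 99.1%
- compound 3 `CNC(=O)N1CCCc2ccc(NC(=O)c3ccccc3-c3ccccc3)cc21`: 60.4%

Compound 1 stands lowest of the three numbers in this assay. Its nearest neighbour is compound 3, whose value lies beyond the scatter above it, and compound 2 lies furthest above, also beyond the scatter. Among the measured compounds shown here, no single-point step between measured compounds is available, so the series gives no direct calibration for the change at hand.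

Compound 4 `CNC(=O)N1CCCc2ccc(NC(=O)c3cccc(-c4ccn(C)n4)c3)cc21` differs from compound 1 by 1-methyl-1H-pyrazol-3-yl in place of 1-(methylsulfonyl)-1H-pyrazol-4-yl on an aromatic carbon. Nothing measured isolates this change; the high value of compound 2 belongs to a differently placed pyrazole on a differently substituted benzamide, and compound 3 carries no pyrazole at all, so neither serves as a reference pair.

Given the wide spread of the three measured numbers in this assay, an upward step of moderate size from compound 1 to compound 4 is expected, though with low confidence. The estimated step is a number 27 percentage points higher from compound 1 to compound 4 (beyond the scatter). Compound 4 is expected to give about 45% in this assay, within a range from 12% to 80%.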

Compound 4, a percentage reported as inhibition, at one concentration (the size of the read-out at that concentration, not a potency): 99.5%
The estimate for compound 4 lay 54.5 percentage points below the measured number; measured number outside the range, above it.
By their numbers in this assay, from the lowest: compound 1; then compound 3; then compounds 2 and 4 (each within the scatter of the next).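

In this assay, 1-methyl-1H-pyrazol-3-yl in place of 1-(methylsulfonyl)-1H-pyrazol-4-yl gives a number 81.5 percentage points higher from compound 1 to compound 4 (beyond the scatter), the first direct sign that the group on this aromatic carbon, meta to a large group, can decide the read-out on the shared core. The change alters both the ring attachment and the group on the pyrazole nitrogen, so this single step does not separate the two. No measurement at hand accounts for the step.

Still open, on these data alone, is which of the two differences carries the step, a question that 1-methyl-1H-pyrazol-4-yl at this carbon would help settle. Also open, as far as these compounds go, is how a carboxylic acid or an aminomethyl group at the same carbon would read out.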